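The compounds below may be only part of what the source reports. "The series", "measured", "known", "first", "only" and "open" are said of these compounds alone.

Measured so far:
Compound 1 `O=C1c2ccccc2C(=O)N1c1ccccc1`: > 100 ug/mL
Compound 2 `CC(C)c1ccccc1N1C(=O)c2ccccc2C1=O`: > 100 ug/mL
Compound 3 `CC(C)c1cccc(N2C(=O)c3ccccc3C2=O)c1`: > 100 ug/mL

In a functional assay on WI-38 cells (Homo sapiens) for cytotoxicity (a higher number here means a weaker inhibitor, a lower number a stronger inhibitor), compound 1 gives > 100 ug/mL, which is a limit of the assay and not a number. Its standing can therefore be told only as a limit, and the same holds for compound 2 and compound 3. The common picture is the limit of > 100 ug/mL in this assay, at which 3 of the 3 values shown sit.

Compound 4 `CC(C)c1ccc(N2C(=O)c3ccccc3C2=O)cc1` has not yet been measured. It departs from compound 1 by one change: isopropyl in place of hydrogen on an aromatic carbon. The new isopropyl sits on an aromatic carbon, para to a large group.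

Among the compounds with values here, two measured steps bear on this, as both make the same exchange of hydrogen for isopropyl on an aromatic carbon. They are a step that the two limits leave unreadable from compound 1 to compound 2 and a step that the two limits leave unreadable from compound 1 to compound 3. Neither has a readable size, so they give no direction and no measure for a further step. What they do show is that compound 2 and compound 3 both stayed at the limit of the assay. No step beyond the scatter is therefore expected in this assay, and a further limit is the likeliest report. The expected step is a step that the limit leaves unreadable from compound 1 to compound 4. Compound 4 is estimated at 130 ug/mL, with an expected range from 70 ug/mL to 250 ug/mL.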

Compound 4, half-maximal inhibitory concentration: > 100 ug/mL
Compound 4: no number, only a limit (the forecaster's own chance of this, stated with the estimate: 80%); the middle value does not contradict the limit.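

In this assay, within the data shown here, compound 4 gives > 100 ug/mL, which is a limit of the assay and not a number, so no step from compound 1 to compound 4 can be read. The compounds shown leave open what any of the four values would be as a number, and whether isopropyl in place of hydrogen on an aromatic carbon changes it at all: the limit of > 100 ug/mL in this assay, at which 4 of the 4 values shown sit.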